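This account rests on a few compounds, and the source may have more. Where it says the series, first, only, none or still open, it means among the compounds named here.

Measured in a functional assay on SW 1116 cells (Homo sapiens) for cytotoxicity, read by MTT assay, with a stated time of 48 h; a lower number here means a stronger inhibitor, a higher number a weaker inhibitor:
- compound 1 `O=C(CSc1nnc(-c2ccncc2)o1)N/N=C/c1ccc([N+](=O)[O-])cc1`: 25800 nM
- compound 2 `O=C(CSc1nnc(-c2ccncc2)o1)N/N=C/c1cccc(F)c1`: 26700 nM

The two compounds cannot be told apart, and compound 2 stands at 26700 nM. For the measured compounds named here, the single measured step, a 1.0-fold higher number from compound 1 to compound 2 (0.01 log units; within the scatter), lies within the scatter, even though it replaces 4-nitrophenyl with 3-fluorophenyl.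

Compound 3 `O=C(CSc1nnc(-c2ccncc2)o1)N/N=C/c1ccccc1F` carries one further change: 2-fluorophenyl in place of 3-fluorophenyl on a carbon with a double bond to nitrogen. In words, 2-fluorophenyl stands in place of 3-fluorophenyl on a carbon with a double bond to nitrogen. Going by the values given here, no measured step exchanges one fluorophenyl for another, so the data give only indirect guidance. With that one step inside the scatter, no step beyond the scatter is expected in this assay, and no direction is favoured. The expected change is a 1.0-fold lower number from compound 2 to compound 3 (0.01 log units; within the scatter). Compound 3 is estimated at 26000 nM, with an expected range of 12000 nM to 52000 nM.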

Compound 3, half-maximal inhibitory concentration: 21500 nM
Compound 3: middle estimate off by 1.2-fold (0.08 log units), on the high side, within the range that was stated.
By their numbers in this assay, from the lowest: compounds 3, 1 and 2 (each within the scatter of the next).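

Exchanging 3-fluorophenyl for 2-fluorophenyl on a carbon with a double bond to nitrogen gives a 1.2-fold lower number from compound 2 to compound 3 (0.09 log units; within the scatter) in this assay, so this direct exchange between two fluorophenyl groups, with the same atoms joined differently, does not separate the compounds. Exchanging 4-nitrophenyl for 2-fluorophenyl at this place gives a 1.2-fold lower number from compound 1 to compound 3 (0.08 log units; within the scatter), and all three substituted phenyl groups shown now lie within the scatter of one another. No independent measurement is available to account for this result.

As far as these compounds go, all three compounds keep a substituted phenyl group at this place, so it remains open whether an amine, a carboxylic acid or a longer chain there would give a step beyond the scatter. From the compounds shown here alone, it also remains open whether any change to the shared core would do so.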